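The source may report more compounds than this note shows. Statements on the series, on what has been measured and on what is new or still open speak of the compounds shown alone.

Compound 1 `COc1ccc(C(=O)/C=C/c2cc(OC)c(OC)c(OC)c2)c2c1C=CC(C)(C)O2` gives 7650 nM in a functional assay on HCT-116 cells (Homo sapiens) for antiproliferative activity, read by MTT assay, with a stated time of 24 h; on this read-out higher numbers stand for weaker inhibition and lower numbers for stronger inhibition.
Compound 2 `COc1ccc(C(=O)/C=C/c2ccc(Br)cc2)c2c1C=CC(C)(C)O2` gives > 10000 nM in this assay, which is a limit of the assay and not a number.

Compound 2 thus stands at the limit of > 10000 nM in this assay, at which 1 of the 2 values shown sits. Compound 3 `COc1ccc(C(=O)/C=C/c2ccc(-n3ccnc3)cc2)c2c1C=CC(C)(C)O2` differs from compound 2 by 1H-imidazol-1-yl in place of bromo on an aromatic carbon. Going by the values given here, no step between measured compounds exists here that could guide this change, so the expectation rests on the structural change alone. For compound 3 a modest step toward stronger inhibition is expected, an at least 1.2-fold lower number from compound 2 to compound 3 (0.09 log units; that floor lies within the scatter). Compound 3 is therefore estimated to give 8000 nM, somewhere within 2000 nM to 40000 nM, with a real chance that only a limit is reported once more.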

Compound 3, half-maximal inhibitory concentration: > 10000 nM
Compound 3 was reported as a limit; the forecaster's own chance of this, stated with the estimate: 45%; middle value at least 1.2-fold (0.09 log units) away from the limit.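

Compound 2 and compound 3 both give a limit and not a number, so no step can be read between them: the limit of > 10000 nM in this assay, at which 2 of the 3 values shown sit. As far as these compounds go, whether 1H-imidazol-1-yl in place of bromo changes inhibition at all stays open.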